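Swapping the piperidine for a formamide on the oxazolidinone side chain

A few compounds are considered here, and "the series" means these few. Any claim that something is new, unique, unknown or untested is made for them only; others in the source may bear on it.

Of the compounds shown here, three sharing one core have been measured in a physicochemical assay for solubility, read by HPLC, with a stated time of 24 h; on this read-out higher numbers stand for higher solubility and lower numbers for lower solubility. Compound 1 `CN1CCN(C[C@H]2CN(c3ccc(-n4cc(-c5ccccn5)cn4)c(F)c3)C(=O)O2)CC1` carries a 4-methylpiperazin-1-yl group on the saturated chain carbon bound to a saturated ring carbon, and in this assay compound 1 gives 1690000 nM. Compound 2 `O=C1O[C@@H](CN2CCCCC2)CN1c1ccc(-n2cc(-c3ccccn3)cn2)c(F)c1` has piperidin-1-yl at that place and gives 219000 nM, the lowest of the three numbers. Compound 3 `O=C1O[C@@H](Cn2ccnn2)CN1c1ccc(-n2cc(-c3ccccn3)cn2)c(F)c1` has 1H-1,2,3-triazol-1-yl there and gives 247000 nM.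

The steps show a 7.7-fold lower number from compound 1 to compound 2 (0.89 log units; beyond the scatter) and a 6.8-fold lower number from compound 1 to compound 3 (0.84 log units; beyond the scatter), whereas a 1.1-fold higher number from compound 2 to compound 3 (0.05 log units; within the scatter).

Compound 4 `O=CNC[C@H]1CN(c2ccc(-n3cc(-c4ccccn4)cn3)c(F)c2)C(=O)O1` is the next step from compound 2: formylamino in place of piperidin-1-yl on a saturated chain carbon bound to a saturated ring carbon. For the measured compounds named here, no measured step covers this exact replacement. The two measured replacements of the 4-methylpiperazin-1-yl group each gave a modest drop, while the exchange of piperidin-1-yl for 1H-1,2,3-triazol-1-yl stayed within the scatter, so a step of the latter kind, at most modest and most likely upward, is expected here: a 1.6-fold higher number from compound 2 to compound 4 (0.20 log units; within the scatter). For compound 4 the estimated value in this assay is 350000 nM, expected to lie between 120000 nM and 1000000 nM.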

Compound 4, solubility: 217000 nM
For compound 4 the middle estimate is 1.6-fold (0.21 log units) above the measured one; the range from low to high includes it.
By their numbers in this assay, from the lowest: compounds 4, 2 and 3 (each within the scatter of the next); then compound 1.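

In this assay the open-chain formylamino, which has no ring and brings a hydrogen-bond donor, cannot be told apart from the ring-bearing groups it is compared with: the data show a 1.0-fold lower number from compound 2 to compound 4 (0.00 log units; within the scatter) and a 1.1-fold lower number from compound 3 to compound 4 (0.06 log units; within the scatter) at this place. With three quite different groups now sitting together on the saturated chain carbon, the one that stands apart among these four compounds is 4-methylpiperazin-1-yl, with a 7.8-fold lower number from compound 1 to compound 4 (0.89 log units; beyond the scatter) on going to formylamino. No evidence on hand explains this grouping or the separate position of compound 1.

As far as these compounds go, what a morpholine or an unsubstituted piperazine would give at this place stays open. So does whether a primary amine on the same chain carbon would fall with compound 1 or with the other three.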